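Moving the ring nitrogen and methyl in a thiazole-bearing agonist

This account rests on a few compounds, and the source may have more. Where it says the series, first, only, none or still open, it means among the compounds named here.

Of the compounds shown here, three of a shared core have been measured in a functional assay for activation of Alpha-1A adrenergic receptor (Homo sapiens), read by calcium flux; on this read-out higher numbers stand for an effect only at larger amounts of compound and lower numbers for an effect already at smaller amounts. Compound 1 `c1ccc(-c2nccs2)c(OCC2=NCCN2)c1` gives 2.51 nM, compound 2 `Cc1ccoc1-c1ccccc1OCC1=NCCN1` gives 3.16 nM, and compound 3 `Cc1csc(-c2ccccc2OCC2=NCCN2)n1` gives 25.1 nM. Compound 3 carries the highest number of the three: its nearest neighbour is compound 2, and the step of a 7.9-fold higher number from compound 2 to compound 3 (0.90 log units; beyond the scatter), while the step of a 10-fold higher number from compound 1 to compound 3 (1.00 log units; beyond the scatter) is larger still.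

Compound 4 `Cc1cc(-c2ccccc2OCC2=NCCN2)sn1` keeps the same atoms as compound 3 but joins them differently: 3-methyl-1,2-thiazol-5-yl in place of 4-methyl-1,3-thiazol-2-yl on an aromatic carbon. For the measured compounds named here, no measured step rearranges a ring in this way. Going by the values given here, the steps that bear on it are those that touch the same ring: a 10-fold higher number from compound 1 to compound 3 (1.00 log units; beyond the scatter) shows that adding the methyl to the thiazole raises the number, and a 1.3-fold higher number from compound 1 to compound 2 (0.10 log units; within the scatter) shows that exchanging one five-membered ring for another can leave the number within the scatter. Since compound 4 keeps the methyl and only shifts the heteroatoms, a step in this assay of modest size in either direction, or none beyond the scatter, is expected; the estimate leans to a slightly lower number than compound 3, giving a 1.7-fold lower number from compound 3 to compound 4 (0.22 log units; within the scatter). Compound 4 is therefore expected to give about 15 nM, with a range from 3 nM to 80 nM.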

Compound 4, half-maximal effective concentration: 158 nM
Beside the measured number, compound 4's estimate is 11-fold (1.02 log units) below it; the measured number lies above the stated range.
By their numbers in this assay, from the lowest: compounds 1 and 2 (each within the scatter of the next); then compound 3; then compound 4.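

In this assay, the rearrangement of compound 3 into compound 4 gives a 6.3-fold higher number from compound 3 to compound 4 (0.80 log units; beyond the scatter) with no change in the heavy atoms, hydrogen-bond donors or hydrogen-bond acceptors counted for the group, so at this place on the aromatic ring the way the ring atoms are joined matters as well as which atoms are present. The earlier exchange of one five-membered ring for another stayed within the scatter, but this position is not always so tolerant: the new group gives a 50-fold higher number from compound 2 to compound 4 (1.70 log units; beyond the scatter) and also a 63-fold higher number from compound 1 to compound 4 (1.80 log units; beyond the scatter) as large steps. Ring exchanges at this place therefore range from no readable change to the largest steps in the set, and compound 4 carries the highest number of the four compounds.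

The compounds shown leave open whether the rise belongs to the 1,2-thiazol-5-yl ring itself or to its combination with the methyl, which the unsubstituted 1,2-thiazol-5-yl ring, or the same ring carrying an amine or a methoxy group in place of the methyl, would help to separate. Nothing available here accounts for the difference between the two methyl-bearing rings.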